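The compounds below may be only part of what the source reports. "The series", "measured", "known", "first", "only" and "open" are said of these compounds alone.

Measured compounds in a functional assay on PC-3 cells (Homo sapiens) for antiproliferative activity, read by XTT assay; a lower number here means a stronger inhibitor, a higher number a weaker inhibitor:

compound 1, `COc1cccc2occ(Cc3coc4ccccc4c3=O)c(=O)c12`: 3490 nM
compound 2, `O=c1c(Cc2coc3cccc(OCc4ccccc4)c3c2=O)coc2ccccc12`: 4830 nM
compound 3, `O=C1c2c(OCC3CCCCC3)cccc2OCC1Cc1coc2ccccc2c1=O`: 9380 nM

Compound 2 sits second highest of the three numbers. Its nearest neighbour is compound 1, whose number lies within the scatter of that of compound 2, and the gap to compound 3 is likewise within the scatter. For the measured compounds named here, the only step that can be cut between measured compounds, a 1.4-fold higher number from compound 1 to compound 2 (0.14 log units; within the scatter), is within the scatter too; so far nothing in the set moves the read-out beyond the scatter.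

Compound 4, `CC(C)COc1cccc2occ(Cc3coc4ccccc4c3=O)c(=O)c12`, differs from compound 2 by isopropyl in place of phenyl on a saturated chain carbon bound to an oxygen on an aromatic ring. Going by the values given here, the one measured step that bears on this site, a 1.4-fold higher number from compound 1 to compound 2 (0.14 log units; within the scatter), shows that even the larger change of adding a phenyl there did not move the number beyond the scatter. Among the compounds with values here, no step from phenyl to isopropyl is measured, and compound 3, which carries a different group at the same oxygen, also gives a number within the scatter of compound 2. Therefore no step beyond the scatter is expected in this assay for compound 4, in either direction.

The step from compound 2 to compound 4 is thus estimated as a 1.0-fold higher number from compound 2 to compound 4 (0.02 log units; within the scatter). Compound 4 is expected at 5000 nM, with a range from 2500 nM to 10000 nM.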

Compound 4, half-maximal inhibitory concentration: 1720 nM
Compound 4: middle estimate off by 2.9-fold (0.46 log units), on the high side; measured number outside the range, below it.
By their numbers in this assay, from the lowest: compound 4; then compounds 1, 2 and 3 (each within the scatter of the next, the first and the last beyond it).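

In this assay the group on a saturated chain carbon bound to an oxygen on an aromatic ring can now be seen to move the read-out beyond the scatter, with isopropyl in place of phenyl giving a 2.8-fold lower number from compound 2 to compound 4 (0.45 log units; beyond the scatter) as a modest step. The earlier change at this site gave only a 1.4-fold higher number from compound 1 to compound 2 (0.14 log units; within the scatter) and stayed within the scatter, whereas isopropyl in place of hydrogen gives a 2.0-fold lower number from compound 1 to compound 4 (0.31 log units; beyond the scatter) and lies just beyond it, so the outcome here depends on which group enters and not simply on whether hydrogen is replaced.

Among pairs that differ in one place, only hydrogen, phenyl and isopropyl have been compared at this carbon, so it remains open whether the lower number is particular to isopropyl or extends to other saturated chains, such as a longer straight chain or a tert-butyl group. On these data alone, how a terminal amine or carboxylic acid at this place would read also remains open. Nothing available here accounts for the difference between isopropyl and phenyl at this site.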